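The source may report more compounds than this note shows. Statements on the series, on what has been measured and on what is new or still open speak of the compounds shown alone.

Working notes on the series.

Within the data shown here, compound 1, `O=c1oc2c(O)c(O)ccc2cc1-c1cccs1`, gives 3230 nM in an assay on CHO cells for displacement of a labelled ligand from adenosine receptor A1 (Homo sapiens) (on this read-out higher numbers stand for weaker inhibition and lower numbers for stronger inhibition), and compound 2, `O=c1oc2c(O)c(O)ccc2cc1-c1ccsc1`, gives 3360 nM in this assay; the only measured single step, a 1.0-fold higher number from compound 1 to compound 2 (0.02 log units; within the scatter), concerns the thiophene attachment and not the hydroxy pattern. Compound 3, `O=c1oc2c(O)cccc2cc1-c1cc(Br)cs1`, stands apart from both: in this assay compound 3 reaches only the limit > 100000 nM, which is a limit of the assay and not a number, as noted in the limit of > 100000 nM in this assay, at which 1 of the 3 values shown sits. Compound 4, `O=c1oc2c(O)c(O)ccc2cc1-c1cc(Br)cs1`, is not yet measured and differs from compound 3 by hydroxy in place of hydrogen on an aromatic carbon. No measured step follows this change directly, so the expectation rests on the spread of the numbers shown: compounds 1 and 2 carry the two hydroxy groups and give measured numbers, whereas compound 3, with one hydroxy group and a bromo on the thiophen-3-yl, sits at the limit. For compound 4 a move of an at least 3.3-fold lower number from compound 3 to compound 4 (0.52 log units; beyond the scatter) toward stronger inhibition is therefore expected, but with wide uncertainty. Compound 4 is estimated at 30000 nM, within 5000 nM to 150000 nM, in this assay.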

Compound 4, inhibition constant: 16300 nM
The estimate for compound 4 lay 1.8-fold (0.26 log units) above the measured number; the range from low to high includes it.
By their numbers in this assay, from the lowest: compounds 1 and 2 (each within the scatter of the next); then compound 4. At a limit, above all of these: compound 3.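

Hydroxy in place of hydrogen on the aromatic carbon, ortho to a hydroxy group, gives an at least 6.1-fold lower number from compound 3 to compound 4 (0.78 log units; beyond the scatter) in this assay, so within this 4-bromothiophen-2-yl pair a measured number appears only with the added hydroxy. On these data alone, the size of that step stays open on one side, as compound 3 stands at a limit of the assay and not at a number: the limit of > 100000 nM in this assay, at which 1 of the 4 values shown sits. With both hydroxy groups kept, bromo in place of hydrogen gives a 5.0-fold higher number from compound 1 to compound 4 (0.70 log units; beyond the scatter), and 4-bromothiophen-2-yl in place of thiophen-3-yl gives a 4.9-fold higher number from compound 2 to compound 4 (0.69 log units; beyond the scatter), while the change of thiophene attachment alone gave a 1.0-fold higher number from compound 1 to compound 2 (0.02 log units; within the scatter).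

The compounds shown leave open whether the hydroxy step carries over to a thiophene without bromo. They also leave open how methoxy or an amine at that aromatic carbon, or chloro in place of bromo, would read.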